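The compounds below may be only part of what the source reports. "The series", "measured", "known", "first", "only" and "open" are said of these compounds alone.

Measured compounds:
- Compound 1, `Cc1oc(-c2ccc(Cl)cc2)nc1CN1CCC(C(=O)NCCCN2C[C@H](C)C[C@H](C)C2)CC1`: in a physicochemical assay for permeability, using PAMPA (on this read-out lower numbers stand for lower permeability and higher numbers for higher permeability), compound 1 gives > 635 10^-6 cm/s, which is a limit of the assay rather than a number.
- Compound 2, `Cc1ccccc1-c1nc(CN2CCC(C(=O)NCCCN3CCCC(CC(C)C)C3)CC2)c(C)o1`: in this assay compound 2 gives 3 10^-6 cm/s.

Compound 1 therefore stands at the limit of > 635 10^-6 cm/s in this assay, at which 1 of the 2 values shown sits; only the limit is known, not where above it the true value lies. Compound 2 sits far lower, but it differs from compound 1 in more than one place, so the two values show only that this kind of structure can span a wide range in this assay.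

Compound 3, `COc1ccc(-c2nc(CN3CCC(C(=O)NCCCN4C[C@H](C)C[C@H](C)C4)CC3)c(C)o2)cc1OC`, differs from compound 1 in a single place: 3,4-dimethoxyphenyl in place of 4-chlorophenyl on an aromatic carbon. Going by the values given here, no measured pair shows this change on its own, so the size of the step has no direct precedent. The step from compound 1 to compound 3 in this assay is expected to be a moderate fall, an at least 3.1-fold lower number from compound 1 to compound 3 (0.50 log units; beyond the scatter), though with compound 1 known only as a limit the true fall could be larger. Compound 3 is estimated to give about 200 10^-6 cm/s, in the range 30 10^-6 cm/s to 635 10^-6 cm/s.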

Compound 3, apparent permeability: 81.9 10^-6 cm/s
Compound 3: middle estimate off by 2.4-fold (0.39 log units), on the high side; the range from low to high includes it.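

Going by these compounds alone, replacing 4-chlorophenyl with 3,4-dimethoxyphenyl on an aromatic carbon of the five-membered ring gives, in this assay, an at least 7.7-fold lower number from compound 1 to compound 3 (0.88 log units; beyond the scatter), the first change at this position that can be read on its own. The entering group has 10 heavy atoms and 2 hydrogen-bond acceptors against 7 and 0 for the leaving group, but a single step cannot separate these differences. The fall may be larger than printed because compound 1 is known only as a limit: the limit of > 635 10^-6 cm/s in this assay, at which 1 of the 3 values shown sits.

Going by these compounds, how 4-methoxyphenyl or plain phenyl would read at this position remains open, and with them whether the fall goes with the loss of the chlorine or the arrival of the methoxy groups. Also open, on these data alone, is whether the same swap would give a similar step on another amine at the far end of the chain.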